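Swapping the Chain on a Ring Amine

The source may report more compounds than this note shows. Statements on the series, on what has been measured and on what is new or still open speak of the compounds shown alone.

Two compounds set the scene. Compound 1 `COc1ccc(CCCN2CCC(=CCC(c3ccccc3)c3ccccc3)CC2)cc1` and compound 2 `Cc1ccc(CCCN2CCC(COC(c3ccccc3)c3ccccc3)CC2)cc1` share a saturated ring bearing an amine nitrogen, with a chain on that nitrogen ending in a benzene ring and a second arm carrying two phenyl groups. In a functional assay on cells (T-cell line, Homo sapiens) for inhibition (on this read-out higher numbers stand for weaker inhibition and lower numbers for stronger inhibition), compound 1 gives 400 nM, and compound 2 gives 200 nM. Compound 2 sits at one end of these two numbers, but its gap to compound 1 falls within the scatter, so the two cannot be told apart.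

Compound 3 `COc1ccc(/C=C/CN2CCC(COC(c3ccccc3)c3ccccc3)CC2)cc1` has not yet been measured. It keeps the core of compound 2 and changes only the chain: 2-(4-methoxyphenyl)ethenyl in place of 2-(4-methylphenyl)ethyl on a saturated chain carbon bound to an amine nitrogen in a ring. Among the measured compounds shown here, no step between measured compounds isolates this change, and compound 1, which also carries a methoxy group on its benzene ring, differs from compound 2 elsewhere too.

With so little to go on, the change from compound 2 to compound 3 is expected to give a 1.5-fold higher number from compound 2 to compound 3 (0.18 log units; within the scatter), a step not beyond the scatter. Compound 3 is therefore estimated at 300 nM, within a range from 100 nM to 1000 nM.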

Compound 3, half-maximal inhibitory concentration: 4300 nM
For compound 3 the middle estimate is 14-fold (1.16 log units) below the measured one, outside the stated range (above it).
By their numbers in this assay, from the lowest: compounds 2 and 1 (each within the scatter of the next); then compound 3.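

Among the compounds shown here, this position on the chain is clearly sensitive: in this assay, the single swap gives a 22-fold higher number from compound 2 to compound 3 (1.33 log units; beyond the scatter), a large move that the two earlier compounds could not reveal, since they differ in more than one place and fall within the scatter of each other. Because higher numbers mean weaker inhibition here, the 2-(4-methoxyphenyl)ethenyl group is much worse at this place than the 2-(4-methylphenyl)ethyl group it replaces, although the two groups are nearly the same size by heavy-atom count and the core stays the same. Nothing available explains why the number rises so sharply.

The swap also changes two features at once, bringing in both a double bond outside the aromatic ring and a methoxy oxygen in place of methyl, so these compounds cannot show which of the two accounts for the loss, or whether both are needed. A 2-(4-methoxyphenyl)ethyl group or a 2-(4-methylphenyl)ethenyl group at the same place would separate the two features, each changing only one of them relative to compound 2.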